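Methyl to Ethyl: From Compound 1 to Compound 4

The source may report more compounds than this note shows. Statements on the series, on what has been measured and on what is new or still open speak of the compounds shown alone.

Of the compounds shown here, three have been tested in an ADME assay on the whole organism with Oryza sativa as the target, tested at 0.1 uM; on this read-out lower numbers stand for a stronger effect and higher numbers for a weaker effect at the one concentration tested. Compound 1 `Cc1ccccc1NC(=O)N[C@H](C)c1ccccc1` gives 100% there, compound 2 `Cc1ccccc1NC(=O)N[C@@H](C)c1ccccc1` gives 100%, and compound 3 `Cc1cccc(NC(=O)N[C@H](C)c2ccccc2)c1` gives 100%. Compound 1 thus stands level with compounds 2 and 3 at the digits shown. For the measured compounds named here, the one step among them, no change at the digits printed from compound 1 to compound 2 (within the scatter), rests on (the fact that compounds 1 and 2 differ only in the configuration as drawn). Compound 4 `CCc1ccccc1NC(=O)N[C@H](C)c1ccccc1` has not yet been measured; it differs from compound 1 by methyl in place of hydrogen on a saturated chain carbon bound to an aromatic carbon. Going by the values given here, no measured step touches this place, and the values of compounds 1, 2 and 3 all sit at the same level, so no step beyond the scatter is expected, the estimated step being no change at the digits printed from compound 1 to compound 4 (within the scatter). Compound 4 is therefore expected to give about 100%, between 88% and 100%.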

Compound 4, a percentage reported as activity, at one concentration (the size of the read-out at that concentration, not a potency): 101%
Beside the measured number, compound 4's estimate is 1 percentage points below it; the whole stated range lies below it.
By their numbers in this assay, from the lowest: compounds 1, 2, 3 and 4 (each within the scatter of the next).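

The methyl to ethyl change gives, in this assay, a number 1 percentage points higher from compound 1 to compound 4 (within the scatter). For the compounds shown here, this is the first reading at this place, a saturated chain carbon bound to an aromatic carbon, and the extra methyl leaves the read-out within the scatter. No evidence at hand bears on this result.

As far as these compounds go, what a propyl chain, an amine or a carboxylic acid would do at this place stays open. So does whether any change to the shared core can move this read-out away from the level of these compounds.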